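Working notes: from compound 3 to compound 4

The source may report more compounds than this note shows. Statements on the series, on what has been measured and on what is new or still open speak of the compounds shown alone.

Values in an ADME assay on NIH3T3 cells (Mus musculus) for cytotoxicity, with a stated time of 72 h (on this read-out higher numbers stand for weaker inhibition and lower numbers for stronger inhibition), so far
- compound 1 `OC[C@H]1O[C@@H](n2cnc3c(NCc4ccccc4Br)ncnc32)[C@H](O)[C@@H]1O` gives > 166000 nM as a limit
- compound 2 `OC[C@H]1O[C@@H](n2cnc3c(NCc4cccc(Br)c4)ncnc32)[C@H](O)[C@@H]1O` gives > 166000 nM as a limit
- compound 3 `COc1cccc(CNc2ncnc3c2ncn3[C@@H]2O[C@H](CO)[C@@H](O)[C@H]2O)c1OC` reads "not determined" (no result reported) in this record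

Compound 3 has no single number, and the only reference near it is the limit of > 166000 nM in this assay, at which 2 of the 3 values shown sit, in this series. The change to compound 4 `OC[C@H]1O[C@@H](n2cnc3c(NCc4ccc(F)cc4F)ncnc32)[C@H](O)[C@@H]1O` is 2,4-difluorophenyl in place of 2,3-dimethoxyphenyl on a saturated chain carbon bound to a nitrogen on an aromatic ring with the shared core untouched. Among the measured compounds shown here, the sole measured step is a step that the two limits leave unreadable from compound 1 to compound 2 and offers no size to carry over. For the measured compounds named here, no step of definite size or direction is therefore expected in this assay, and compound 4 is expected to stay close to that limit because the limit of > 166000 nM in this assay, at which 2 of the 3 values shown sit, is all the series shows. For compound 4 the estimated value is 166000 nM with an expected range of 80000 nM to 250000 nM in this read-out.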

Compound 4, half-maximal inhibitory concentration: > 166000 nM
Compound 4: no number, only a limit; the forecaster's own chance of this, stated with the estimate: 80%; the middle value lies on the limit itself.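

In this assay compound 4 gives > 166000 nM, a limit, so the steps from compound 1 and from compound 2 to compound 4 cannot be read. The compounds shown leave open whether any group at this place gives a number rather than a limit in this assay.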